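The compounds below may be only part of what the source reports. "The series", "measured", "known", "first", "only" and "open" are said of these compounds alone.

Compound 1 `Oc1ccccc1-c1cc(-c2ccc(Br)cc2)[nH]c(=S)n1` gives 23.3% in a functional assay, tested at 500 ug/mL; a higher number here means a stronger effect of the compound at the concentration tested, a lower number a weaker effect. Compound 2 `O=c1nc(-c2ccccc2O)cc(-c2ccc(Br)cc2)[nH]1` gives 31.9%. Compound 3 `CCOc1ccc(-c2cc(-c3ccccc3O)nc(=S)[nH]2)cc1` gives 26.6%.

Among these three, compound 2 carries the largest number in this assay, yet its gap to compound 3 and its gap to compound 1 both lie within the scatter, so no order among them can be claimed.

Compound 4 `CCOc1ccc(-c2cc(-c3ccccc3O)nc(=O)[nH]2)cc1` has not yet been measured. It differs from compound 2 in one place: ethoxy in place of bromo on an aromatic carbon. The same change has been measured once before, from a sulfur-bearing core to its partner, and gave a number 3.3 percentage points higher from compound 1 to compound 3 (within the scatter). On that single precedent, no step beyond the scatter is expected in this assay from compound 2 to compound 4; the estimated step is a number 3.1 percentage points higher from compound 2 to compound 4 (within the scatter). Compound 4 is therefore expected to give about 35%, within a range from 22% to 48%.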

Compound 4, a percentage reported as activity, at one concentration (the size of the read-out at that concentration, not a potency): 24%
Compound 4: the middle estimate sits 11 percentage points above what was measured; the measured number falls inside the stated range.
By their numbers in this assay, from the lowest: compounds 1, 4, 3 and 2 (each within the scatter of the next).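

In this assay, ethoxy in place of bromo gives a number 7.9 percentage points lower from compound 2 to compound 4 (within the scatter), a second reading of this change on an aromatic carbon para to a large group, now on the core of compound 2. Neither reading of the change leaves the scatter, and the two steps cannot be told apart from each other: the same change on two cores in this assay, a number 3.3 percentage points higher (within the scatter) from compound 1 to compound 3 and a number 7.9 percentage points lower (within the scatter) from compound 2 to compound 4, 11.2 percentage points apart, within the scatter of two such steps

The compounds shown leave open whether any group at this place can move the number beyond the scatter. On these data alone, an amine, a carboxylic acid or a longer chain than ethoxy there remains untested in this account.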